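Azepanyl for dimethylamino on a shared core

The compounds below may be only part of what the source reports. "The series", "measured", "known", "first", "only" and "open" are said of these compounds alone.

Measured so far:
compound 1, `CC(C(=O)NCc1ccc(C(F)(F)F)nc1N(C)C)c1ccc(NS(C)(=O)=O)c(F)c1`, 19.1 nM in a functional assay on CHO-K1 cells for antagonist activity at transient receptor potential cation channel subfamily V member 1 (Homo sapiens), read by FLIPR; on this read-out higher numbers stand for weaker inhibition and lower numbers for stronger inhibition
compound 2, `CC(C(=O)NCc1ccc(C(F)(F)F)nc1N1CCC(OC(=O)C(C)(C)C)CC1)c1ccc(NS(C)(=O)=O)c(F)c1`, 2 nM

Compound 1 has the highest number of the two; compound 2 lies a good deal lower, beyond the scatter. Compound 3, `CC(C(=O)NCc1ccc(C(F)(F)F)nc1N1CCCCCC1)c1ccc(NS(C)(=O)=O)c(F)c1`, is not yet measured. It differs from compound 1 in one place: azepan-1-yl in place of dimethylamino on an aromatic carbon. Within the data shown here, no step between measured compounds is available for this exact exchange. Compound 3 is expected to give a lower number than compound 1, a step of a 3.2-fold lower number from compound 1 to compound 3 (0.50 log units; beyond the scatter), because compound 2, which also carries a ring in this position, gives 2 nM. The estimate for compound 3 is 6 nM, within 1.5 nM to 20 nM.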

Compound 3, inhibition constant: 0.8 nM
The estimate for compound 3 lay 7.5-fold (0.88 log units) above the measured number, outside the stated range (below it).
By their numbers in this assay, from the lowest: compound 3; then compound 2; then compound 1.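

In this assay the exchange on the aromatic carbon next to the ring nitrogen gives a 24-fold lower number from compound 1 to compound 3 (1.38 log units; beyond the scatter) and so shows directly that this position accepts azepan-1-yl with a large gain in inhibition. The gain comes with the same counts of hydrogen-bond donors and acceptors in the leaving and entering groups. No measurement shown accounts for the size of this step. The compounds shown leave open whether pyrrolidin-1-yl or an open chain such as dipropylamino would give a similar number. They also leave open how morpholin-4-yl, with its ring oxygen, would compare.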